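This account rests on a few compounds, and the source may have more. Where it says the series, first, only, none or still open, it means among the compounds named here.

Measured so far in a functional assay on HCT-116 cells (Homo sapiens) for cytotoxicity, read by MTT assay, with a stated time of 24 h; a lower number here means a stronger inhibitor, a higher number a weaker inhibitor:
- Compound 1 `COc1ccc(/C=C\C(=O)O)c(OCc2cn(-c3ccc(NC(C)=O)cc3)nn2)c1CC=C(C)C`: "not determined" (no result reported)
- Compound 2 `COc1ccc(/C=C\C(=O)O)c(OCc2cn(-c3ccc(NC(=O)c4ccccc4)cc3)nn2)c1CC=C(C)C`: 16400 nM
- Compound 3 `COc1ccc(/C=C\C(=O)O)c(OCc2cn(-c3ccccc3F)nn2)c1CC=C(C)C`: "not determined" (no result reported)

Compound 3 has no place on the numeric scale, since its entry reads "not determined" (no result reported). Compound 1 is in the same situation, which leaves a single numeric result in the series. Compound 4 `COc1ccc(/C=C\C(=O)O)c(OCc2cn(-c3ccc(CO)cc3)nn2)c1CC=C(C)C` has yet to be measured. The structural change is 4-(hydroxymethyl)phenyl in place of 2-fluorophenyl on an aromatic nitrogen, with 4-(hydroxymethyl)phenyl in place of 2-fluorophenyl on an aromatic nitrogen. For the measured compounds named here, no measured step exists to scale this change, so no step beyond the scatter is expected in this assay, and no direction is favoured. Going by the values given here, the only numeric anchor is compound 2 at 16400 nM. For compound 4, the estimated value is 20000 nM, with an expected range of 7000 nM to 60000 nM.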

Compound 4, half-maximal inhibitory concentration: 31700 nM
Beside the measured number, compound 4's estimate is 1.6-fold (0.20 log units) below it; low and high end bracket the measured number.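

In this assay, the aromatic carbon that carries the substituent on the phenyl ring now has its first readable step: hydroxymethyl in place of benzamido gives a 1.9-fold higher number from compound 2 to compound 4 (0.29 log units; within the scatter). The two groups therefore cannot be told apart here, and the swap of 2-fluorophenyl for 4-(hydroxymethyl)phenyl cannot be read, as compound 3 has no number. Nothing available offers an explanation for this result. Still open, going by these compounds, is whether an amine, a carboxylic acid or a longer chain on that carbon would give a step beyond the scatter.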